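The source may report more compounds than this note shows. Statements on the series, on what has been measured and on what is new or still open speak of the compounds shown alone.

Measured compounds in an ADME assay on cells (Homo sapiens) for cytotoxicity, read by polymerase chain reaction, with a stated time of 3 days; a lower number here means that less compound is tolerated, a higher number that more compound is tolerated:
- compound 1, `Cc1nc(NCc2ccccc2)nc(N[C@@H]2C[C@H](CO)[C@@H](O)[C@H]2O)c1-c1nc2cnccc2s1`: 25000 nM
- compound 2, `Cc1nc(N[C@H](C)c2ccccc2)nc(N[C@@H]2C[C@H](CO)[C@@H](O)[C@H]2O)c1-c1nc2cnccc2s1`: 25000 nM
- compound 3, `Cc1cc2sc(-c3c(C)nc(N[C@H](C)c4ccc(OC(F)(F)F)cc4)nc3N[C@@H]3C[C@H](CO)[C@@H](O)[C@H]3O)nc2c(C)n1`: 20000 nM

Compound 2 differs from compound 1 by methyl in place of hydrogen on a saturated chain carbon bound to an aromatic carbon and a nitrogen on an aromatic ring. The step in this assay is no change at the digits printed from compound 1 to compound 2 (within the scatter), so this change did not move the half-maximal cytotoxic concentration at the digits shown.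

Compound 3 carries a different core from compound 1; the difference between the two cores is not broken down here. Its value sits within the scatter of both compound 1 and compound 2, so no order among the three measured compounds can be read from these numbers.

Compound 4, `CCc1nc(C)cc2sc(-c3c(C)nc(N[C@H](C)c4ccc(OC(F)(F)F)cc4)nc3N[C@@H]3C[C@H](CO)[C@@H](O)[C@H]3O)nc12`, is the unmeasured member. It differs from compound 3 by methyl in place of hydrogen on a saturated chain carbon bound to an aromatic carbon. This is the same kind of change as that from compound 1 to compound 2, though not the same: there the saturated chain carbon is bound to an aromatic carbon and a nitrogen on an aromatic ring, here it is bound to an aromatic carbon only.

Going by the values given here, for compound 4 the expected step from compound 3 in this assay is no change at the digits printed from compound 3 to compound 4 (within the scatter), since the one earlier instance of this kind of change gave no change at the digits printed from compound 1 to compound 2 (within the scatter). Among the compounds with values here, the expected value for compound 4 is therefore 20000 nM, with a range of 9000 nM to 40000 nM, the width reflecting that the place of the change is not identical and only one precedent exists.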

Compound 4, half-maximal cytotoxic concentration: 23000 nM
Beside the measured number, compound 4's estimate is 1.2-fold (0.06 log units) below it; the measured number falls inside the stated range.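

In this assay, methyl in place of hydrogen on a saturated chain carbon bound to an aromatic carbon gives a 1.2-fold higher number from compound 3 to compound 4 (0.06 log units; within the scatter), and the two instances of this kind of change agree across the two cores: the same change on two cores in this assay, no change at the digits printed (within the scatter) from compound 1 to compound 2 and a 1.2-fold higher number (0.06 log units; within the scatter) from compound 3 to compound 4, 1.2-fold (0.06 log units) apart, within the scatter of two such steps. Within these two pairs, then, adding the methyl leaves the half-maximal cytotoxic concentration unmoved beyond the usual scatter, even though the places are not identical, the earlier one being a saturated chain carbon bound to an aromatic carbon and a nitrogen on an aromatic ring. This does not show that the change is without effect on other cores or at other places in the series, as two pairs are a thin basis, and it says nothing about any read-out other than this one.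

The compounds shown leave open whether the same carbon tolerates anything beyond methyl to ethyl in this assay, for example a longer chain, an amine or a carboxylic acid. They also leave open whether a step beyond the scatter can be found in this assay at all, as every pair shown here stays within it.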